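A few compounds are considered here, and "the series" means these few. Any claim that something is new, unique, unknown or untested is made for them only; others in the source may bear on it.

In a functional assay on HCC827 cells (Homo sapiens) for antiproliferative activity, read by MTT assay, with a stated time of 72 h (a higher number here means a weaker inhibitor, a lower number a stronger inhibitor), compound 2 `CN1CCN(c2ccc(Nc3ncc4nc(Nc5ccc(F)cc5)n([C@@H]5CCCN(C(=O)CO)C5)c4n3)cc2)CC1` gives 66 nM, the lowest of the two numbers recorded so far. Its nearest neighbour is compound 1 `CN1CCN(c2ccc(Nc3ncc4nc(Nc5ccc(F)cc5)n([C@H]5CCN(C(=O)OC(C)(C)C)C5)c4n3)cc2)CC1`, which in this assay gives 580 nM; the step of an 8.8-fold lower number from compound 1 to compound 2 (0.94 log units; beyond the scatter) came with 1-((hydroxymethyl)carbonyl)piperidin-3-yl in place of 1-(tert-butoxycarbonyl)pyrrolidin-3-yl on an aromatic nitrogen. Compound 3 `CCOC(=O)CN1CC[C@H](n2c(Nc3ccc(F)cc3)nc3cnc(Nc4ccc(N5CCN(C)CC5)cc4)nc32)C1` differs from compound 2 at the same position: 1-((ethoxycarbonyl)methyl)pyrrolidin-3-yl in place of 1-((hydroxymethyl)carbonyl)piperidin-3-yl on an aromatic nitrogen. For the measured compounds named here, only one measured step speaks to this position, and it changed the ring size and the group on its nitrogen at once, so it cannot say which of the two mattered. Compound 3 brings back the five-membered ring of compound 1 but with a different group on its nitrogen, so a number between those of compound 1 and compound 2 is expected, that is a 2.4-fold higher number from compound 2 to compound 3 (0.38 log units; beyond the scatter). The expected value for compound 3 is 160 nM, within 50 nM to 550 nM.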

Compound 3, half-maximal inhibitory concentration: 1810 nM
The estimate for compound 3 lay 11-fold (1.05 log units) below the measured number, and the stated range ends below it.
By their numbers in this assay, from the lowest: compound 2; then compound 1; then compound 3.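

With the five-membered ring kept, the step of a 3.1-fold higher number from compound 1 to compound 3 (0.49 log units; beyond the scatter) comes with (ethoxycarbonyl)methyl in place of tert-butoxycarbonyl on the amine nitrogen in the ring, so the group on that nitrogen moves the number on its own. The step of a 27-fold higher number from compound 2 to compound 3 (1.44 log units; beyond the scatter) is larger, but it changes the ring size and the group together, and compound 3 ends up above both earlier compounds rather than between them. Nothing available here explains either shift.

How much of the larger step belongs to the ring size stays open, as no pair shown has the same group on the five-membered and the six-membered ring. Also open, as far as these compounds go, is how a carboxylic acid in place of the ethyl ester of compound 3 would read.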